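This account rests on a few compounds, and the source may have more. Where it says the series, first, only, none or still open, it means among the compounds named here.

Compound 1, `O=C(COc1ccc(-c2ccccc2)cc1)Nc1cccc(-c2nc3ncccc3o2)c1`, gives 630 nM in an assay on brain for inhibition of Fatty-acid amide hydrolase 1 (Rattus norvegicus); on this read-out lower numbers stand for stronger inhibition and higher numbers for weaker inhibition.
Compound 2, `O=C(COc1ccc(C2CCCCC2)cc1)Nc1cccc(-c2nc3ncccc3o2)c1`, gives 2600 nM.
Compound 3, `O=C(COc1ccc(-c2ccccc2)cc1)Nc1ccc(-c2nc3ncccc3[nH]2)cc1`, gives 620 nM.

Compound 1 and compound 3 carry different cores; how the two cores differ is not broken down here, and their two values lie within the scatter of each other. Going from compound 1 to compound 2 makes one change, cyclohexyl in place of phenyl on an aromatic carbon, and that step gave a 4.1-fold higher number from compound 1 to compound 2 (0.62 log units; beyond the scatter). Compound 4, `O=C(COc1ccc(C2CCCCC2)cc1)Nc1ccc(-c2nc3ncccc3[nH]2)cc1`, has not yet been measured. It is made from compound 3 by the same change, (cyclohexyl in place of phenyl on an aromatic carbon), at a place described in the same words. A step of a 4.0-fold higher number from compound 3 to compound 4 (0.61 log units; beyond the scatter) is expected for compound 4, because the earlier step on the other core was a 4.1-fold higher number from compound 1 to compound 2 (0.62 log units; beyond the scatter) and the starting point of compound 3 is 620 nM. Compound 4 is therefore estimated at 2500 nM, most likely between 1000 nM and 6500 nM.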

Compound 4, half-maximal inhibitory concentration: 1500 nM
Compound 4: the middle estimate sits 1.7-fold (0.22 log units) above what was measured; the measured number falls inside the stated range.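

In this assay, cyclohexyl in place of phenyl again gives a higher number on the second core, a 2.4-fold higher number from compound 3 to compound 4 (0.38 log units; beyond the scatter). This step agrees with the earlier one as far as the scatter allows: the same change on two cores in this assay, a 4.1-fold higher number (0.62 log units; beyond the scatter) from compound 1 to compound 2 and a 2.4-fold higher number (0.38 log units; beyond the scatter) from compound 3 to compound 4, 1.7-fold (0.23 log units) apart, within the scatter of two such steps. The change therefore carries over in direction and, within the scatter, in size between these two cores, but two cores cannot show that it would hold on any further core, nor do they explain why the number rises.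

The compounds shown leave open what a methyl group, an amine or a carboxylic acid would do in the place of phenyl or cyclohexyl. They also leave open whether the step would hold with a longer chain leading to the amide.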